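The source may report more compounds than this note shows. Statements on the series, on what has been measured and on what is new or still open speak of the compounds shown alone.

In an assay on microsomes from intestine for inhibition of acyl-CoA:cholesterol acyltransferase (Oryctolagus cuniculus) (on this read-out lower numbers stand for stronger inhibition and higher numbers for weaker inhibition), compound 1 `CCCCCCCCCCCCN1NN=C(NC(=O)Nc2c(C(C)C)cccc2C(C)C)N1` gives 14 nM, and compound 2 `CCCCCCCCCCCCCN1NN=C(NC(=O)Nc2c(C(C)C)cccc2C(C)C)N1` gives 9 nM; compound 2 stands at the lower of the two numbers, yet the step of a 1.6-fold lower number from compound 1 to compound 2 (0.19 log units; within the scatter) lies within the scatter. Compound 3 `COC(=O)CCCCCCCCCCN1NN=C(NC(=O)Nc2c(C(C)C)cccc2C(C)C)N1` carries methoxycarbonyl in place of propyl on a saturated chain carbon, ten or more bonds along the chain from an amine nitrogen in a ring. Among the compounds with values here, the one measured step bears on the same chain but only lengthens it, and no measured step tests a methoxycarbonyl ending there. A modest rise in the number, slightly beyond the scatter, is therefore expected, amounting to a 2.8-fold higher number from compound 2 to compound 3 (0.44 log units; beyond the scatter). Compound 3 is estimated at 25 nM, with a range from 7 nM to 90 nM.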

Compound 3, half-maximal inhibitory concentration: 4700 nM
Beside the measured number, compound 3's estimate is 190-fold (2.27 log units) below it, outside the stated range (above it).
By their numbers in this assay, from the lowest: compounds 2 and 1 (each within the scatter of the next); then compound 3.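

In this assay, the end of the chain proves far from indifferent: methoxycarbonyl in place of propyl gives a 520-fold higher number from compound 2 to compound 3 (2.72 log units; beyond the scatter) and methoxycarbonyl in place of ethyl gives a 340-fold higher number from compound 1 to compound 3 (2.53 log units; beyond the scatter). The earlier methyl step on this chain stayed within the scatter, whereas this change on a saturated chain carbon lies far beyond it. No measured evidence accounts for the rise. From the compounds shown here alone, whether a carboxylic acid, a primary amide or a hydroxyl at the chain end would behave like methoxycarbonyl remains open, as does whether a longer chain carrying methoxycarbonyl would recover the lower numbers.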